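The source may report more compounds than this note shows. Statements on the series, on what has been measured and on what is new or still open speak of the compounds shown alone.

Measured in a functional assay on PANC-1 cells (Homo sapiens) for antiproliferative activity, read by MTT assay, with a stated time of 48 h; on this read-out lower numbers stand for stronger inhibition and higher numbers for weaker inhibition:
- compound 1 `CC(=O)Oc1ccccc1C(=O)NCC[Se]C#N`: 2100 nM
- compound 2 `CC(=O)Oc1ccccc1C(=O)[Se]CC[Se]C#N`: 18900 nM
- compound 3 `C[Se]CC(NC(=O)c1ccccc1OC(C)=O)C(=O)O`: 26100 nM

Compound 1 has the lowest number of these three, so it is the strongest inhibitor here. The next molecule, compound 4 `CC(=O)Oc1ccccc1C(=O)NCCSC#N`, has not been measured. It differs from compound 1 in one place: a group of 3 heavy atoms (1 carbon, 1 nitrogen, 1 sulfur; no ring) in place of a group of 3 heavy atoms (1 carbon, 1 nitrogen, 1 selenium; no ring), on a saturated chain carbon, two bonds along the chain from an amide-type nitrogen. In plain terms, sulfur takes the place of selenium, and the rest of the molecule stays the same.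

Within the data shown here, no measured step makes this swap, so the data give no direct guide to its size. The closest evidence is a 9.0-fold higher number from compound 1 to compound 2 (0.95 log units; beyond the scatter), but that change sits elsewhere, on a carbonyl carbon, and it offers only a loose hint of how far numbers can move in this small set. Because compound 1 already holds the lowest value at 2100 nM, a rise seems more likely than a fall, though this is uncertain.

The expected change is a 2.9-fold higher number from compound 1 to compound 4 (0.46 log units; beyond the scatter) in this assay, a modest move toward weaker inhibition. For compound 4 the estimated value is 6000 nM, with an expected range from 1800 nM to 20000 nM.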

Compound 4, half-maximal inhibitory concentration: 17700 nM
Estimate against measurement, compound 4: 3.0-fold (0.47 log units) below; the range from low to high includes it.
By their numbers in this assay, from the lowest: compound 1; then compounds 4, 2 and 3 (each within the scatter of the next).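

In this assay, putting sulfur in place of selenium on a saturated chain carbon, two bonds along the chain from an amide-type nitrogen, gives an 8.4-fold higher number from compound 1 to compound 4 (0.93 log units; beyond the scatter) and shows that this single atom in the cyanosulfanyl group's position has a measurable effect on the result. The other new step, a 1.1-fold lower number from compound 2 to compound 4 (0.03 log units; within the scatter), shows that the sulfur compound and the compound with two selenium atoms cannot be told apart in this assay. No measurement shown here explains why the swap has this effect.

As far as these compounds go, it remains open how an amine in place of the cyanosulfanyl group, or a longer chain leading to it, would behave. Among these compounds, only one pair of compounds makes the sulfur-for-selenium swap, so its size on a different core is unknown.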